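A Second Trifluoroethyl Ester on a Stable Core

This account rests on a few compounds, and the source may have more. Where it says the series, first, only, none or still open, it means among the compounds named here.

Compound 2 `C[C@@H](O)[C@H]1C(=O)N2C(C(=O)OCC(F)(F)F)=C(S[C@@H]3CN[C@H](C(=O)Nc4cccc(C(=O)O)c4)C3)[C@H](C)[C@H]12` is the starting point. In an ADME assay for metabolic stability, read by LC-MS, with a stated time of 3 h, at pH 6.5, tested at 50 uM (a higher number here means that more of the compound is left, a lower number that less of the compound is left), compound 2 gives > 95%, which is a limit of the assay, not a number. Compound 1 `C[C@@H](O)[C@H]1C(=O)N2C(C(=O)OCOC(=O)C3CCCCC3)=C(S[C@@H]3CN[C@H](C(=O)Nc4cccc(C(=O)O)c4)C3)[C@H](C)[C@H]12` gives > 95%, also a limit. Compound 3 `COC(=O)OCOC(=O)C1=C(S[C@@H]2CN[C@H](C(=O)Nc3cccc(C(=O)O)c3)C2)[C@H](C)[C@@H]2[C@@H]([C@@H](C)O)C(=O)N12` gives > 95%, again a limit. Since (the limit of > 95% in this assay, at which 3 of the 3 values shown sit), the steps a step that the two limits leave unreadable from compound 1 to compound 2, a step that the two limits leave unreadable from compound 1 to compound 3 and a step that the two limits leave unreadable from compound 2 to compound 3 cannot be sized; they all alter the ester group on the other carbonyl oxygen, not the carboxy. Compound 4 `C[C@@H](O)[C@H]1C(=O)N2C(C(=O)OCC(F)(F)F)=C(S[C@@H]3CN[C@H](C(=O)Nc4cccc(C(=O)OCC(F)(F)F)c4)C3)[C@H](C)[C@H]12` differs from compound 2 by 2,2,2-trifluoroethyl in place of hydrogen on an oxygen next to a carbonyl group. Among the measured compounds shown here, no measured step touches this oxygen, so the expected step of a number at least 5 percentage points lower from compound 2 to compound 4 (that floor lies within the scatter) rests only on the limit of compound 2. Compound 4 is expected to give 90%, estimated between 70% and 99%.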

Compound 4, percent of the compound remaining: > 95%
Compound 4: only a limit was reported; the forecaster's own chance of this, stated with the estimate: 55%; at least 5 percentage points between middle value and limit.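

No step can be read from compound 2 to compound 4, since both are reported only as limits in this assay: the limit of > 95% in this assay, at which 4 of the 4 values shown sit.

The compounds shown leave open whether 2,2,2-trifluoroethyl in place of hydrogen changes how much compound remains.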